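This account rests on a few compounds, and the source may have more. Where it says the series, first, only, none or still open, it means among the compounds named here.

Of the compounds shown here, three that share one core have been tested in a functional assay on NCI-H1975 cells (Homo sapiens) for inhibition, read by sulforhodamine B assay, tested at 10 uM; on this read-out lower numbers stand for less inhibition and higher numbers for more inhibition at the one concentration tested (going by the name of the read-out). Compound 1 `CN(C)c1ccc(C2CC(c3ccc(-n4cncn4)cc3)=NN2C(=O)CCCl)cc1` gives -0.7%. Compound 2 `COC(=O)CC(=O)N1N=C(c2ccc(-n3cncn3)cc2)CC1c1ccc(N(C)C)cc1` gives 1.5%. Compound 3 `CN(C)c1ccc(C2CC(c3ccc(-n4cncn4)cc3)=NN2C(=O)/C=C/c2ccccc2)cc1` gives -2.3%; its number is the lowest of the three, yet the steps of a number 1.6 percentage points lower from compound 1 to compound 3 (within the scatter) and a number 3.8 percentage points lower from compound 2 to compound 3 (within the scatter) both lie within the scatter, as does a number 2.2 percentage points higher from compound 1 to compound 2 (within the scatter). Within the data shown here, compound 4 `CN(C)c1ccc(C2CC(c3ccc(-n4cncn4)cc3)=NN2S(=O)(=O)c2ccc(C#N)cc2)cc1` has not yet been measured. (4-cyanophenyl)sulfonyl in place of (2-phenylethenyl)carbonyl on an amine nitrogen in a ring No measured step contains a sulfonyl group, so the three steps bear on this change only by showing that every exchange made so far in this part of the molecule left the read-out unmoved. The step of a number 2.3 percentage points higher from compound 3 to compound 4 (within the scatter) is therefore expected to stay within the scatter. Compound 4 is estimated to give 0%, somewhere between -10% and 12%.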

Compound 4, a percentage reported as inhibition, at one concentration (the size of the read-out at that concentration, not a potency): 22.6%
Compound 4: middle estimate off by 22.6 percentage points, on the low side, and the stated range ends below it.
By their numbers in this assay, from the lowest: compounds 3, 1 and 2 (each within the scatter of the next); then compound 4.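

In this assay, the amine nitrogen in the ring turns out not to be indifferent to what it carries: (4-cyanophenyl)sulfonyl in place of (2-phenylethenyl)carbonyl gives a number 24.9 percentage points higher from compound 3 to compound 4 (beyond the scatter). The same group gives a number 21.1 percentage points higher from compound 2 to compound 4 (beyond the scatter) against ((methoxycarbonyl)methyl)carbonyl and a number 23.3 percentage points higher from compound 1 to compound 4 (beyond the scatter) against (2-chloroethyl)carbonyl, so it stands apart from all three carbonyl-linked groups. Nothing available explains this step. Going by these compounds, compound 4 brings in the sulfonyl link and the nitrile together, and which of them carries the step stays open. Also open, on these data alone, is what a plain phenylsulfonyl or a methylsulfonyl group would give.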